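The source may report more compounds than this note shows. Statements on the series, on what has been measured and on what is new or still open speak of the compounds shown alone.

Within the data shown here, compound 1 `CCCCNC(=O)/C=C/c1c(/C=C/c2ccc(OC)cc2)cc(OC)cc1OC` gives 2080 nM in a functional assay on B16-F10 cells (Mus musculus) for inhibition, read by MTT assay, with a stated time of 48 h (on this read-out lower numbers stand for stronger inhibition and higher numbers for weaker inhibition), the lowest of the three numbers measured so far. Compound 2 `COc1ccc(/C=C/c2cc(OC)cc(OC)c2/C=C/C(=O)N2CCCCC2)cc1` gives 9750 nM in this assay, and compound 3 `COc1ccc(/C=C/c2cc(OC)cc(OC)c2/C=C/C(=O)N2CCC(c3ccccc3)CC2)cc1` gives 9180 nM; the two lie within the scatter of each other. Compound 4 `COc1ccc(/C=C/c2cc(OC)cc(OC)c2/C=C/C(=O)N(CC(C)C)CC(C)C)cc1` is not yet measured; it differs from compound 1 by diisobutylamino in place of butylamino on a carbonyl carbon. Among the measured compounds shown here, two measured steps bear on this change, since both also exchange butylamino on the carbonyl carbon for an amine without the amide hydrogen: a 4.7-fold higher number from compound 1 to compound 2 (0.67 log units; beyond the scatter) and a 4.4-fold higher number from compound 1 to compound 3 (0.64 log units; beyond the scatter). A modest shift to a higher number is therefore expected for compound 4 as well. Compound 4 is estimated at 7000 nM, with a range of 2500 nM to 20000 nM. This estimate corresponds to an expected 3.4-fold higher number from compound 1 to compound 4 (0.53 log units; beyond the scatter).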

Compound 4, half-maximal inhibitory concentration: 4850 nM
Compound 4: middle estimate off by 1.4-fold (0.16 log units), on the high side; the range from low to high includes it.
By their numbers in this assay, from the lowest: compound 1; then compounds 4, 3 and 2 (each within the scatter of the next).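

In this assay, diisobutylamino, which has no ring, also lies beyond the scatter from butylamino, at a 2.3-fold higher number from compound 1 to compound 4 (0.37 log units; beyond the scatter), so the shift is not confined to the piperidin-1-yl and 4-phenylpiperidin-1-yl amides. The steps of a 1.9-fold lower number from compound 3 to compound 4 (0.28 log units; within the scatter) and a 2.0-fold lower number from compound 2 to compound 4 (0.30 log units; within the scatter) both lie within the scatter, leaving compounds 2, 3 and 4 as one cluster apart from compound 1. No measurement shown explains this separation.

Open, going by these compounds, is whether the amide hydrogen or the butyl chain carries the difference; methylbutylamino, which keeps the butyl chain without the amide hydrogen, would separate the two.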